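Chain substituent exchange at the saturated ring carbon

A few compounds are considered here, and "the series" means these few. Any claim that something is new, unique, unknown or untested is made for them only; others in the source may bear on it.

Compound 1 `C[C@@H](c1ccc(Cl)cc1)N1Cc2cncn2C(C[C@@H](O)c2ccccc2)S1(=O)=O` and compound 2 `C[C@@H](c1ccc(Cl)cc1)N1Cc2cncn2C(C[C@H](O)c2ccccc2)S1(=O)=O` differ only in the drawn configuration of one stereocentre on the chain. Going by the values given here, in an assay on isolated protein for inhibition of Aromatase (Homo sapiens), tested at 1 uM (a higher number here means more inhibition at the concentration tested (going by the name of the read-out), a lower number less inhibition), compound 1 gives 6% and compound 2 gives 6%; the step of no change at the digits printed from compound 1 to compound 2 (within the scatter) is the only measured step, and it concerns a stereocentre alone (the fact that one of compounds 1 and 2 is drawn with a defined configuration and the other without, at the place where they differ), so it says nothing about the exchange that follows. Compound 3 `COC(C)(C)CC1n2cncc2CN([C@@H](C)c2ccc(Cl)cc2)S1(=O)=O` differs from compound 2 by 1-methoxy-1-methylethyl in place of hydroxy(phenyl)methyl on a saturated chain carbon bound to a saturated ring carbon. Among the compounds with values here, no measured step bears on this change. Compound 3 is expected to stay near the low level of compound 2, a step of a number 2 percentage points higher from compound 2 to compound 3 (within the scatter), giving an estimate of 8% with a range from 0% to 25%.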

Compound 3, a percentage reported as inhibition, at one concentration (the size of the read-out at that concentration, not a potency): 17%
Compound 3: middle estimate off by 9 percentage points, on the low side; the range from low to high includes it.
By their numbers in this assay, from the lowest: compounds 1 and 2 (each within the scatter of the next); then compound 3.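

In this assay, 1-methoxy-1-methylethyl in place of hydroxy(phenyl)methyl shows that this position can move the read-out: a number 11 percentage points higher from compound 2 to compound 3 (beyond the scatter). The exchange reads the same from the other drawn configuration of the chain stereocentre: a number 11 percentage points higher from compound 1 to compound 3 (beyond the scatter). Nothing available gives a cause for this step.

Going by these compounds, the exchange removes the six-membered aromatic ring and the hydrogen-bond donor together, so the share of each stays open. On these data alone, how an amine or a carboxylic acid would read at this place also remains open.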